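Removing a Ring Methyl From Compound 1

The source may report more compounds than this note shows. Statements on the series, on what has been measured and on what is new or still open speak of the compounds shown alone.

Measured compounds:
Compound 1 `CCCNc1nc(NCc2ccc(C(=O)N3CCC(C(=O)NCc4ccc(F)cc4)CC3)cc2)c2cc(C)ccc2n1` — 5200 nM
Compound 2 `CCNc1nc(NCc2ccc(C(=O)N[C@H]3C[C@@H]3c3ccccc3)cc2)c2cc(C)ccc2n1` — 1800 nM

Both compounds were tested in a functional assay on SW480 cells (Homo sapiens) for inhibition, read by luminescence and resazurin assay, with a stated time of 3 days; on this read-out lower numbers stand for stronger inhibition and higher numbers for weaker inhibition. On this read-out compound 1 gives 5200 nM, the higher of the two numbers and therefore the weaker inhibitor of the pair. For the measured compounds named here, its nearest neighbour is compound 2, which in this assay gives 1800 nM; the two structures differ in several places at once, so their values show only that compound 2 sits clearly lower, beyond the usual scatter, and not which change is responsible.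

Compound 3 `CCCNc1nc(NCc2ccc(C(=O)N3CCC(C(=O)NCc4ccc(F)cc4)CC3)cc2)c2ccccc2n1` has not yet been measured. It differs from compound 1 in one place only: hydrogen in place of methyl on an aromatic carbon. The change is hydrogen in place of methyl on an aromatic carbon of a six-membered aromatic ring of carbon only, part of a fused system of two rings, meta to a fused ring and para to a fused ring.

Going by the values given here, no pair of measured compounds differing only in this methyl is available, so there is no direct precedent for the size of this step. Because compound 1 already gives 5200 nM, a small loss of a single carbon is expected to shift the number only modestly, most likely toward slightly weaker inhibition, with a step from compound 1 to compound 3 estimated at a 1.3-fold higher number from compound 1 to compound 3 (0.13 log units; within the scatter) in this assay, near the edge of the scatter. Compound 3 is therefore expected to give about 7000 nM, within a range of 2500 nM to 20000 nM.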

Compound 3, half-maximal inhibitory concentration: 5700 nM
Beside the measured number, compound 3's estimate is 1.2-fold (0.09 log units) above it; low and high end bracket the measured number.
By their numbers in this assay, from the lowest: compound 2; then compounds 1 and 3 (each within the scatter of the next).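

In this assay, hydrogen in place of methyl on this aromatic carbon gives a 1.1-fold higher number from compound 1 to compound 3 (0.04 log units; within the scatter), so the methyl can go without a difference that this read-out can separate from repeat scatter. For the compounds shown here, this is the first direct reading of the methyl's contribution, as compound 1 and compound 2 differ in several places at once and their values could not isolate any single change. No information on hand gives a reason for this result.

Only methyl and hydrogen appear on this carbon in the compounds shown, so it remains open whether a different group there, such as a methoxy group, a chlorine atom, an amine or a carboxylic acid, would move the number beyond the scatter. Going by these compounds, it also remains open whether the same change would read the same way on compound 2, where the rest of the molecule differs, so the result for this one pair cannot yet be taken as a general rule for this position.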